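This account rests on a few compounds, and the source may have more. Where it says the series, first, only, none or still open, it means among the compounds named here.

Compound 1 `CN(C)CCCn1cc[n+](C)c1/C=N/O` in a physicochemical assay for lipophilicity (a lower number here means a more polar compound, a higher number a more lipophilic compound), gives only the limit < -3. Compound 2 `C[n+]1ccn(CC[N+](C)(C)C)c1/C=N/O` gives -2.61. Compound 3 `CC[n+]1ccn(CCCC(C)(C)[N+](=O)[O-])c1/C=N/O` gives -1.8.

Of the two numbers shown, compound 2 stands lowest; the value of compound 3 lies higher by a margin beyond the scatter, and the remaining value is a limit rather than a number. Compound 4 `C[n+]1ccn(CCCS(C)(=O)=O)c1/C=N/O` differs from compound 2 by a group of 5 heavy atoms (2 carbon, 2 oxygen, 1 sulfur; no ring) in place of a group of 4 heavy atoms (3 carbon, 1 nitrogen; no ring), on a saturated chain carbon, two bonds along the chain from an aromatic nitrogen. Within the data shown here, one measured step touches the same place: a number at least 0.39 log units higher from compound 1 to compound 2 (beyond the scatter), a swap of one group for another that starts from a limit (the limit of < -3 in this assay, at which 1 of the 3 values shown sits), so its full size is unknown. Compound 4 is expected to move upward by a number 0.91 log units higher from compound 2 to compound 4 (beyond the scatter). Compound 4 is estimated at -1.7, most likely between -2.5 and -0.9.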

Compound 4, distribution coefficient: -2.7
Compound 4: middle estimate off by 1.00 log units, on the high side; measured number outside the range, below it.
By their numbers in this assay, from the lowest: compounds 4 and 2 (each within the scatter of the next); then compound 3. At a limit, below all of these: compound 1.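

In this assay, (methylsulfonyl)methyl, which has no net charge, takes the place of a group with net charge +1, on a saturated chain carbon, two bonds along the chain from an aromatic nitrogen, and the two compounds cannot be told apart: a number 0.09 log units lower from compound 2 to compound 4 (within the scatter). For this pair at this chain carbon, then, losing the net charge of the group goes with no readable difference. With methylsulfonyl in place of dimethylamino on a saturated chain carbon, three bonds along the chain from an aromatic nitrogen, the step reads: a number at least 0.30 log units higher from compound 1 to compound 4 (that floor lies within the scatter). Compound 1 stands at a limit, so the full size of this step cannot be read: the limit of < -3 in this assay, at which 1 of the 4 values shown sits.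

Open, going by these compounds, is whether another group at this place, such as a carboxylic acid or a simple longer carbon chain, would stand apart from compounds 2 and 4.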